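Propargyloxy position on the shared core: compound 3

A few compounds are considered here, and "the series" means these few. Any claim that something is new, unique, unknown or untested is made for them only; others in the source may bear on it.

Going by the values given here, compound 2 `C#CCOc1ccc(-c2cc(-c3cccc(OCC#C)c3)nc(-c3ccccc3)n2)cc1` has the lower of the two numbers so far in an assay on BTI-TN-5B1-4 cells for inhibition of Amine oxidase [flavin-containing] B (Homo sapiens), read by fluorescence and Amplex Red, using microsomes, with a stated time of 30 min; a higher number here means a weaker inhibitor, a lower number a stronger inhibitor: compound 2 gives 17700 nM. Compound 1 `C#CCOc1cccc(-c2cc(-c3cccc(OCC#C)c3)nc(N)n2)c1` carries two 3-(propargyloxy)phenyl groups, and in this assay compound 1 gives 22100 nM, which lies within the scatter of the value of compound 2, so nothing separates the two, though they also differ in a second place. Compound 3 `C#CCOc1cccc(-c2cc(-c3cccc(OCC#C)c3)nc(-c3ccccc3)n2)c1` is to be measured. It differs from compound 2 in one place: 3-(propargyloxy)phenyl in place of 4-(propargyloxy)phenyl on an aromatic carbon. Among the compounds with values here, no measured step of this kind exists yet. Within the data shown here, the expectation is therefore no change beyond the scatter in this assay, in either direction, the placement of the propargyloxy group on one ring being the only change. Compound 3 is expected to give 18000 nM in this assay, within 8000 nM to 45000 nM. The expected step is a 1.0-fold higher number from compound 2 to compound 3 (0.01 log units; within the scatter).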

Compound 3, half-maximal inhibitory concentration: 23400 nM
Beside the measured number, compound 3's estimate is 1.3-fold (0.11 log units) below it; the measured number falls inside the stated range.
By their numbers in this assay, from the lowest: compounds 2, 1 and 3 (each within the scatter of the next).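

Moving the propargyloxy group on one ring gives the first one-place reading at this position: in this assay the change from 4-(propargyloxy)phenyl to 3-(propargyloxy)phenyl gives a 1.3-fold higher number from compound 2 to compound 3 (0.12 log units; within the scatter), so the two placements are not separated. Going by these compounds alone, compound 3 also gives the first one-place reading at the other site, where phenyl in place of amino gives a 1.1-fold higher number from compound 1 to compound 3 (0.02 log units; within the scatter), and these two groups are not separated either. Nothing measured here speaks to the reason for either reading.

As far as these compounds go, all three compounds lie within the scatter of each other, so it remains open whether the number in this assay responds to any change at these two sites. A carboxylic acid or a tertiary amine in place of the propargyloxy group, or a longer alkyne chain, would test this position more sharply.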